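This account rests on a few compounds, and the source may have more. Where it says the series, first, only, none or still open, it means among the compounds named here.

Measured compounds:
- Compound 1 `O=C(O)c1ccc(C(=O)/C(=C\c2ccc(O)c([N+](=O)[O-])c2)SCc2ccc(Br)cc2)cc1`: 50000 nM
- Compound 2 `O=C(/C(=C\c1ccc(O)c([N+](=O)[O-])c1)SCc1ccc(Br)cc1)c1ccc(O)cc1O`: > 100000 nM
- Compound 3 `O=C(/C(=C\c1ccc(O)c([N+](=O)[O-])c1)SCc1ccc(Br)cc1)C1CCNC1`: > 100000 nM

Going by the values given here, in a functional assay on DU-145 cells (Homo sapiens) for inhibition, read by trypan blue exclusion, with a stated time of 96 h (a higher number here means a weaker inhibitor of growth, a lower number a stronger inhibitor of growth), compound 1 gives 50000 nM, the only true number in the set. Compound 2 shows > 100000 nM, which is a limit of the assay. Compound 3 shows > 100000 nM, which is also a limit.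

The next compound, compound 4 `CN1CCN(/C=C(/SCc2ccc(Br)cc2)C(=O)c2ccc(C(=O)O)cc2)CC1[N+](=O)[O-]`, departs from compound 1 at a different place: 4-methyl-3-nitropiperazin-1-yl in place of 4-hydroxy-3-nitrophenyl on a double-bonded chain carbon bound to a double-bonded chain carbon.

The measured steps are an at least 2.0-fold higher number from compound 1 to compound 2 (0.30 log units; that floor lies within the scatter) and an at least 2.0-fold higher number from compound 1 to compound 3 (0.30 log units; that floor lies within the scatter), and both change the group on a carbonyl carbon, not the group changed here. The third is a step that the two limits leave unreadable from compound 2 to compound 3. None of them tests this replacement directly, so they offer only weak guidance.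

With compound 1 at 50000 nM as the only anchor, no shift beyond the scatter is expected, only a slight lean toward weaker growth inhibition. The estimated step is a 1.4-fold higher number from compound 1 to compound 4 (0.15 log units; within the scatter). For compound 4 the expected value is 70000 nM, with an estimated range from 25000 nM to 170000 nM.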

Compound 4, concentration for 50% growth inhibition: 10000 nM
Compound 4: the middle estimate sits 7.0-fold (0.85 log units) above what was measured; measured number below the stated range.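

In this assay, putting 4-methyl-3-nitropiperazin-1-yl in place of 4-hydroxy-3-nitrophenyl gives a 5.0-fold lower number from compound 1 to compound 4 (0.70 log units; beyond the scatter). This place on the double-bonded chain carbon therefore does not need an aromatic ring of carbon or a hydrogen-bond donor for growth inhibition, since the non-aromatic ring, which has neither, gives the stronger inhibitor of the pair. The earlier steps all changed the group on a carbonyl carbon, and their sizes cannot be read because they end at a limit: the limit of > 100000 nM in this assay, at which 2 of the 4 values shown sit.

The compounds shown leave open which part of the new group accounts for the step: the ring, the methyl or the nitro group. On these data alone, a plain piperazin-1-yl or a morpholine ring at this place would begin to separate these, and whether the step holds with other groups on the carbonyl carbon also remains open.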